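Amide aryl exchange in a cell cytotoxicity series

The source may hold more compounds than are shown below. What is called first, only, known or untested is meant among the compounds shown, and "the series" means these compounds.

Measured so far:
- Compound 1, `CCc1ccc(NC(=O)c2cccc(/C=C3\CC(=O)N(c4ccccc4)C3=O)c2)cc1`: in an ADME assay on HCT-116 cells (Homo sapiens) for cytotoxicity, read by MTT assay, with a stated time of 72 h (on this read-out higher numbers stand for weaker inhibition and lower numbers for stronger inhibition), compound 1 gives > 100000 nM
- Compound 2, `CCc1cccc(NC(=O)c2cccc(/C=C3\CC(=O)N(Cc4ccccc4)C3=O)c2)c1`: in this assay compound 2 gives 80600 nM
- Compound 3, `CCCCCN1C(=O)C/C(=C\c2cccc(C(=O)Nc3cccc(CC)c3)c2)C1=O`: in this assay compound 3 gives 75300 nM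

Compound 1 returns only a limit of the assay and no number, sitting at the limit of > 100000 nM in this assay, at which 1 of the 3 values shown sits. Within the data shown here, compounds 2 and 3 both carry a measured number, and the single one-place step between them, a 1.1-fold lower number from compound 2 to compound 3 (0.03 log units; within the scatter), is within the scatter, so the two values show no difference beyond it.

Compound 4, `O=C(Nc1cccc(F)c1)c1cccc(/C=C2\CC(=O)N(c3ccccc3)C2=O)c1`, differs from compound 1 by 3-fluorophenyl in place of 4-ethylphenyl on an amide-type nitrogen. Among the measured compounds shown here, no measured step touches the group on this amide-type nitrogen; the only measured step concerns the substituent on the ring nitrogen and is within the scatter. There is therefore no basis in the series for expecting a step beyond the scatter in this assay, in either direction, and compound 4 is expected to remain at or near the limit where compound 1 sits.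

Compound 4 is estimated at 100000 nM, with a range from 40000 nM to 250000 nM, an expected step of a number no higher from compound 1 to compound 4 (the limit leaves the size open).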

Compound 4, half-maximal inhibitory concentration: > 100000 nM
Compound 4: only a limit was reported; the forecaster's own chance of this, stated with the estimate: 60%; the middle value lies on the limit itself.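

Among these compounds, compound 1 and compound 4 both stand at a limit of the assay, so no step between them can be read: the limit of > 100000 nM in this assay, at which 2 of the 4 values shown sit. The compounds shown leave open whether any group on the amide-type nitrogen changes the number in this assay at all.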